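A few compounds are considered here, and "the series" means these few. Any claim that something is new, unique, unknown or untested is made for them only; others in the source may bear on it.

Of the compounds shown here, three sharing one core have been measured in an assay on HEK293 cells for antagonist activity at P2X purinoceptor 7 (Homo sapiens), read by fluorescence, with a stated time of 2 h; a higher number here means a weaker inhibitor, a lower number a stronger inhibitor. Compound 1 `O=C(c1ccc(Cl)c(C(F)(F)F)c1)N1CCC(n2cncc2-c2ccc(OS(=O)(=O)c3cccc(Br)c3)cc2)CC1` gives 896 nM; compound 2 `O=C(c1ccc(Cl)c(C(F)(F)F)c1)N1CCC(n2cncc2-c2ccc(OS(=O)(=O)c3cccc([N+](=O)[O-])c3)cc2)CC1` gives 249 nM; compound 3 `CNC(=O)c1cccc(S(=O)(=O)Oc2ccc(-c3cncn3C3CCN(C(=O)c4ccc(Cl)c(C(F)(F)F)c4)CC3)cc2)c1` gives 112 nM. The change from bromo to nitro on the aromatic carbon was a 3.6-fold lower number from compound 1 to compound 2 (0.56 log units; beyond the scatter), from bromo to methylcarbamoyl an 8.0-fold lower number from compound 1 to compound 3 (0.90 log units; beyond the scatter), and from nitro to methylcarbamoyl a 2.2-fold lower number from compound 2 to compound 3 (0.35 log units; beyond the scatter), so compound 3 stands lowest of the three, beyond the scatter against both others. Compound 4 `CCN(CC)C(=O)c1cccc(S(=O)(=O)Oc2ccc(-c3cncn3C3CCN(C(=O)c4ccc(Cl)c(C(F)(F)F)c4)CC3)cc2)c1` differs from compound 3 only in that (diethylamino in place of methylamino on a carbonyl carbon). For the measured compounds named here, none of the measured steps touches this amide, so no step bears directly on the change. Compound 4 is therefore expected to stay close to its parent, with a 1.8-fold higher number from compound 3 to compound 4 (0.25 log units; within the scatter) no more than modest. The estimate for compound 4 is 200 nM, within 70 nM to 600 nM.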

Compound 4, half-maximal inhibitory concentration: 202 nM
Beside the measured number, compound 4's estimate is 1.0-fold (0.00 log units) below it; the measured number falls inside the stated range.
By their numbers in this assay, from the lowest: compounds 3, 4 and 2 (each within the scatter of the next, the first and the last beyond it); then compound 1.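

In this assay, diethylamino in place of methylamino on this carbonyl carbon gives a 1.8-fold higher number from compound 3 to compound 4 (0.26 log units; within the scatter), so the amide hydrogen and the smaller group are not needed to keep the number in this range. The diethylcarbamoyl group still holds its advantage over bromo, with a 4.4-fold lower number from compound 1 to compound 4 (0.65 log units; beyond the scatter), and it stays level with nitro, with a 1.2-fold lower number from compound 2 to compound 4 (0.09 log units; within the scatter). Nothing available explains these results. From the compounds shown here alone, whether a carboxylic acid, a primary amide or a cyclic amine such as morpholine would fit at this place remains open. So does how far a longer chain on the amide nitrogen could go before the number rises.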